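The source may report more compounds than this note shows. Statements on the series, on what has been measured and on what is new or still open speak of the compounds shown alone.

In an ADME assay on MSTO-211H cells (Homo sapiens) for inhibition, read by trypan blue exclusion, with a stated time of 72 h (a higher number here means a weaker inhibitor of growth, a lower number a stronger inhibitor of growth), compound 1 (`O=C(/C=C/c1cccc([N+](=O)[O-])c1)c1ccccc1`) gives 5100 nM and compound 2 (`O=C(/C=C/c1ccccc1)c1ccccc1C(F)(F)F`) gives 8500 nM on the same read-out. For the measured compounds named here, these two values lie within the usual scatter of each other, so compound 2 stands level with compound 1 on the only numbers available. Compound 3 (`O=C(/C=C/c1ccccc1)c1ccccc1[N+](=O)[O-]`) has not yet been measured. It differs from compound 2 by nitro in place of trifluoromethyl on an aromatic carbon, ortho to a large group (nitro in place of trifluoromethyl on an aromatic carbon). No measured pair isolates this change, so its size is not shown directly. Compound 1 also carries a nitro group and gives 5100 nM in the same range as compound 2, which offers only modest support for expecting little change. The estimated step of a 1.3-fold lower number from compound 2 to compound 3 (0.12 log units; within the scatter) stays within the scatter in this assay with no firm direction expected. Compound 3 is estimated at 6500 nM with an expected range of 2500 nM to 17000 nM in this measurement.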

Compound 3, concentration for 50% growth inhibition: 9800 nM
Compound 3: middle estimate off by 1.5-fold (0.18 log units), on the low side; the range from low to high includes it.
By their numbers in this assay, from the lowest: compounds 1, 2 and 3 (each within the scatter of the next).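

In this assay, placing nitro in place of trifluoromethyl on an aromatic carbon, ortho to a large group, gives a 1.2-fold higher number from compound 2 to compound 3 (0.06 log units; within the scatter), so the two groups stand level at this position. For the compounds shown here, this pair offers the first direct reading of the change, whereas compound 1 differs from compound 2 in more than one place and could offer only indirect support. No measurement on hand explains why the two groups read alike.

On these data alone, it remains open whether an amine, a carboxylic acid or a methyl group on the same aromatic carbon would also stay level with these two groups. As far as these compounds go, it is equally open whether the same exchange would read alike on a different aromatic carbon of the shared core.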